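Side-chain variation in a diterpenoid series: compound 4

The source may hold more compounds than are shown below. What is called first, only, known or untested is meant among the compounds shown, and "the series" means these compounds.

Measured compounds in a functional assay on cells (Panel NCI-60 (60 carcinoma cell lines), Homo sapiens) for inhibition; a higher number here means a weaker inhibitor, a lower number a stronger inhibitor:
Compound 1 `C[C@H]1C[C@@H](O)[C@@]23C1=C[C@@]1(C)CC[C@](C)(C[C@H](O)[C@H](O)C(C)(C)O)[C@H]1[C@@H]2CC[C@@H]3C` gives 18000 nM.
Compound 2 `C[C@H]1CC[C@@]23C1=C[C@@]1(C)CC[C@](C)(C[C@H](O)[C@H](O)[C@@](C)(O)CO)[C@H]1[C@@H]2CC[C@@H]3C` gives 18000 nM.
Compound 3 `C[C@H]1CC[C@@]23C1=C[C@@]1(C)CC[C@](C)(C[C@H](O)C(=O)[C@@](C)(O)CO)[C@H]1[C@@H]2CC[C@@H]3C` gives 18000 nM.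

Compound 3 stands level with compound 1 and compound 2 at the digits shown; its nearest neighbour in this assay is compound 1 and its furthest is compound 2, and both gaps lie within the scatter. The three measured compounds share a core and differ only in the side chain and in a hydroxyl on the core, yet none of these changes moved the number.

Compound 4 `C[C@H]1CC[C@@]23C1=C[C@@]1(C)CC[C@](C)(C[C@H](O)[C@H](O)C(C)(C)O)[C@H]1[C@@H]2CC[C@@H]3C` is not yet measured. It differs from compound 3 in the side chain: a group of 6 heavy atoms (4 carbon, 2 oxygen; no ring) in place of a group of 7 heavy atoms (4 carbon, 3 oxygen; no ring), on a saturated chain carbon bound to an oxygen on a saturated carbon and a saturated chain carbon. Within the data shown here, the one measured step that touches this part of the molecule is the exchange of one side-chain group for another of the same size no change at the digits printed from compound 2 to compound 3 (within the scatter), and it produced no shift beyond the scatter. Compound 4 also carries the same side chain as compound 1, which sits at the same level as the others.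

On this basis compound 4 is expected to stay where compound 3 stands, with a step of no change at the digits printed from compound 3 to compound 4 (within the scatter). The estimate for compound 4 in this assay is 18000 nM, with a range from 9000 nM to 36000 nM.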

Compound 4, half-maximal inhibitory concentration: 18000 nM
Estimate against measurement, compound 4: no gap at the digits printed; measured number inside the range.
By their numbers in this assay, from the lowest: compounds 1, 2, 3 and 4 (each within the scatter of the next).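

In this assay, placing 1,2-dihydroxy-2-methylpropyl on this saturated chain carbon, in place of the larger group with its carbonyl, gives no change at the digits printed from compound 3 to compound 4 (within the scatter), so the side chain tolerates this further exchange as well. Among these compounds, compound 4 also makes it possible to look at two single hydroxy groups separately, which the earlier compounds did not allow: hydrogen in place of hydroxy on a saturated chain carbon, two bonds along the chain from an oxygen on a saturated carbon, gives no change at the digits printed from compound 2 to compound 4 (within the scatter), and hydrogen in place of hydroxy on a saturated ring carbon gives no change at the digits printed from compound 1 to compound 4 (within the scatter), so neither hydroxy group is needed to hold this level when it alone is removed. Nothing available here explains why the number stays put across these changes.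

On these data alone, all four compounds carry a short side chain with hydroxy groups, so it stays open whether an amine, a carboxylic acid or a longer chain at this place would shift the number. As far as these compounds go, it also stays open what happens when the hydroxy groups on the side chain are replaced together rather than one at a time.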